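The compounds below may be only part of what the source reports. "The series", "measured", "known", "first", "only" and "open" are said of these compounds alone.

Of the compounds shown here, two sharing one core have been measured in a functional assay on CHO cells for agonist activity at Free fatty acid receptor 1 (Homo sapiens), read by FLIPR and calcium flux; a higher number here means that more compound is needed for the effect, a lower number that less compound is needed. Compound 1 `CCCOc1ccc(C)c(-c2cccc(COc3ccc(OCC(=O)O)c(F)c3)c2)c1` gives 610 nM, and compound 2 `COc1ccc(C)c(-c2cccc(COc3ccc(OCC(=O)O)c(F)c3)c2)c1` gives 260 nM. Among the measured compounds shown here, compound 2 thus stands at the lowest of the two numbers, and the single step available, a 2.3-fold lower number from compound 1 to compound 2 (0.37 log units; beyond the scatter), comes from hydrogen in place of ethyl on a saturated chain carbon bound to an oxygen on an aromatic ring.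

Compound 3 `CCOc1ccc(-c2cccc(COc3ccc(OCC(=O)O)c(F)c3)c2)cc1` is the next compound, not yet measured. Compared with compound 2 the change is 4-ethoxyphenyl in place of 5-methoxy-2-methylphenyl on an aromatic carbon: the ring that carries the alkoxy group keeps the same atoms but is joined differently, at an aromatic carbon meta to a large group. For the measured compounds named here, no measured step covers this rearrangement; the only step shows that shortening the alkoxy chain lowered the number modestly, and an ethoxy group sits between the two chain lengths already seen. The step from compound 2 to compound 3 is therefore expected to be small, a 1.5-fold higher number from compound 2 to compound 3 (0.19 log units; within the scatter), and compound 3 is estimated at 400 nM, within 150 nM to 1100 nM.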

Compound 3, half-maximal effective concentration: 360 nM
Estimate against measurement, compound 3: 1.1-fold (0.05 log units) above; the range from low to high includes it.
By their numbers in this assay, from the lowest: compounds 2, 3 and 1 (each within the scatter of the next, the first and the last beyond it).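

Until this point only the length of the alkoxy chain had varied, whereas this change rebuilds the ring itself. In this assay putting 4-ethoxyphenyl in place of 5-methoxy-2-methylphenyl gives a 1.4-fold higher number from compound 2 to compound 3 (0.14 log units; within the scatter) and so no difference that can be told from scatter, even though the methyl group is gone and the same atoms are joined differently on this aromatic carbon. Nothing available explains why the two compounds read so alike.

Several things changed at once here, so the share of the methyl group, of the chain length and of the alkoxy group's place on the ring cannot be separated. On these data alone, it also remains open how the number would respond to a quite different group on this aromatic carbon, such as an aminophenyl group or a phenyl ring carrying a butoxy chain.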